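Changing the aryl group and watching cell tolerance

A few compounds are considered here, and "the series" means these few. Any claim that something is new, unique, unknown or untested is made for them only; others in the source may bear on it.

Measured compounds:
Compound 1, `Cc1ccccc1-c1nn(-c2ccc(F)cc2F)cc1CNC1CCN(S(C)(=O)=O)CC1`: > 20000 nM
Compound 2, `Cc1ccc(-c2nn(-c3ccc(F)cc3F)cc2CNCCN2CCN(C)CC2)cc1`: > 20000 nM

Both compounds were tested in an ADME assay on Huh-7 cells (Homo sapiens) for cytotoxicity; a lower number here means that less compound is tolerated, a higher number that more compound is tolerated. Compound 1 gives only a limit of the assay, > 20000 nM, and not a number. Compound 2 also gives only a limit, > 20000 nM. Going by the values given here, compound 2 therefore stands at the limit of > 20000 nM in this assay, at which 2 of the 2 values shown sit, together with the one other value shown. Among the compounds with values here, no step between measured compounds can be counted, as neither compound has a number.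

Compound 3, `CN1CCN(CCNCc2cn(-c3ccc(F)cc3F)nc2-c2ccccc2Cl)CC1`, is not yet measured. It differs from compound 2 by 2-chlorophenyl in place of 4-methylphenyl on an aromatic carbon. With both measured compounds at the limit, no change in tolerance beyond the scatter is expected in this assay: a step that the limit leaves unreadable from compound 2 to compound 3. Compound 3 is expected to give about 25000 nM, with a range from 12000 nM to 60000 nM, and most probably the assay will again report only a limit.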

Compound 3, half-maximal cytotoxic concentration: > 20000 nM
Compound 3: only a limit was reported; the forecaster's own chance of this, stated with the estimate: 80%; the middle value lies beyond the limit too.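

In this assay compound 3 gives > 20000 nM, which is again only a limit and not a number. No step from compound 2 to compound 3 can be read, as all the compounds shown share one limit: the limit of > 20000 nM in this assay, at which 3 of the 3 values shown sit. The compounds shown leave open whether 2-chlorophenyl and 4-methylphenyl differ in cell tolerance at all.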